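From trifluoromethoxy to methoxy: one group changed

The source may report more compounds than this note shows. Statements on the series, on what has been measured and on what is new or still open speak of the compounds shown alone.

Measured values (a functional assay on KB cells (Homo sapiens) for inhibition, read by MTT assay, with a stated time of 24 h, tested at 10 ug/mL; on this read-out lower numbers stand for less inhibition of growth and higher numbers for more inhibition of growth at the one concentration tested):
compound 1 `O=C(CCCCC(S)CCS)Nc1ccc(F)cc1` gives 13.3%
compound 2 `O=C(CCCCC(S)CCS)Nc1ccc(OC(F)(F)F)cc1` gives 15%

On these numbers compound 2 gives 15% and sits within the scatter of compound 1, so the two cannot be put in order. Compound 3 `COc1ccc(NC(=O)CCCCC(S)CCS)cc1` keeps the shared core and is not yet measured. Compared with compound 2 the change is (methyl in place of trifluoromethyl on an oxygen on an aromatic ring), methyl in place of trifluoromethyl on an oxygen on an aromatic ring, or trifluoromethoxy to methoxy.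

For the measured compounds named here, the one measured step that bears on this (a number 1.7 percentage points higher from compound 1 to compound 2 (within the scatter)) put trifluoromethoxy in place of fluoro on an aromatic carbon, and it lies within the scatter. Going by the values given here, no measured pair tests the new change directly. Since compound 1 stands at 13.3% and compound 2 at 15% in this assay with that gap inside the scatter, no step beyond the scatter is expected here, in either direction. The estimated step (a number 1 percentage points lower from compound 2 to compound 3 (within the scatter)) stays inside the scatter. The estimate for compound 3 is 14% with an expected range (5% to 27%).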

Compound 3, percent growth inhibition at one concentration: 8.93%
Estimate against measurement, compound 3: 5.1 percentage points above; the range from low to high includes it.
By their numbers in this assay, from the lowest: compounds 3, 1 and 2 (each within the scatter of the next).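

In this assay, methyl in place of trifluoromethyl on an oxygen on an aromatic ring gives a number 6.1 percentage points lower from compound 2 to compound 3 (within the scatter), and methoxy in place of fluoro on an aromatic carbon gives a number 4.4 percentage points lower from compound 1 to compound 3 (within the scatter). The trifluoromethyl group, with its four heavy atoms, and the methyl group, with its one, therefore cannot be told apart on this read-out, and the same holds for the fluoro and methoxy groups at this place on the ring, so that three different groups there now stand within the scatter of one another and no order can be drawn among them. Nothing available gives a reason for these numbers or says what the read-out reflects in the cells.

What the compounds shown leave open is whether any group at this place can move the number in this assay beyond the scatter, for example an amine or a carboxylic acid on the aromatic ring. From the compounds shown here alone, it is equally open whether a longer chain in place of the shared chain would do so, or whether such a change would matter more than any change on the ring.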